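Methylation of a Ring Amide Nitrogen in Cyclic Disulfide Peptides

The compounds below may be only part of what the source reports. "The series", "measured", "known", "first", "only" and "open" are said of these compounds alone.

The measured compounds are:
compound 1, `CC(=O)N[C@@H]1CSSC(C)(C)[C@H](C(N)=O)NC(=O)[C@@H](CC(=O)O)N(C)C(=O)CNC(=O)[C@@H](CCCN=C(N)N)NC1=O`, 137000 nM
compound 2, `CC(=O)N[C@@H]1CSSC(C)(C)[C@H](C(N)=O)NC(=O)[C@@H](CC(=O)O)N(C)C(=O)CNC(=O)[C@@H](CCCN=C(N)N)N(C)C1=O`, 23400 nM
compound 3, `CC(=O)N[C@@H]1CSSC(C)(C)[C@H](C(N)=O)NC(=O)[C@@H](CC(=O)O)NC(=O)CNC(=O)[C@H](CCCN=C(N)N)NC1=O`, 4120 nM

In a functional assay (plasma) for inhibition, with Canis familiaris (Canis lupus familiaris) as the target (on this read-out higher numbers stand for weaker inhibition and lower numbers for stronger inhibition), compound 1 gives 137000 nM. Compound 2 carries the change methyl in place of hydrogen on an amide-type nitrogen in a ring and, in this assay, the step is a 5.9-fold lower number from compound 1 to compound 2 (0.77 log units; beyond the scatter). Compound 3 has the lowest number of the three in this assay; the difference between the core of compound 3 and the core of compound 1 is not broken down here, and the two values simply show compound 3 well ahead of compound 1 and of compound 2.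

Compound 4 is `CC(=O)N[C@@H]1CSSC(C)(C)[C@H](C(N)=O)NC(=O)[C@@H](CC(=O)O)NC(=O)CNC(=O)[C@H](CCCN=C(N)N)N(C)C1=O`; it has not yet been measured in this assay. It differs from compound 3 by methyl in place of hydrogen on an amide-type nitrogen in a ring. For the measured compounds named here, this is the same kind of change as the one from compound 1 to compound 2, though the surroundings are not identical: in compound 3 the ring atom six ring bonds away bears two methyl groups (1 heavy atom each), whereas in compound 1 that ring atom bears a methyl group (1 heavy atom). Going by the values given here, because the one measured instance of this change, a 5.9-fold lower number from compound 1 to compound 2 (0.77 log units; beyond the scatter), lowered the number by a modest but clear margin, compound 4 is expected to show a step of similar size, a 5.5-fold lower number from compound 3 to compound 4 (0.74 log units; beyond the scatter). Among the compounds with values here, since only a single such pair is known and the core of compound 3 is not the core of compound 1, the expectation is held loosely. The estimate for compound 4 in this assay is 750 nM, with an expected range from 200 nM to 3000 nM.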

Compound 4, half-maximal inhibitory concentration: 1790 nM
Estimate against measurement, compound 4: 2.4-fold (0.38 log units) below; the range from low to high includes it.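

In this assay, methyl in place of hydrogen on an amide-type nitrogen in a ring again lowered the number, a 2.3-fold lower number from compound 3 to compound 4 (0.36 log units; beyond the scatter), so the change points the same way on both cores shown. As far as these two pairs can tell, the size of the step also carried over from the core of compound 1 to the core of compound 3, since the gap between the two steps does not exceed what two such steps would scatter by: the same change on two cores in this assay, a 5.9-fold lower number (0.77 log units; beyond the scatter) from compound 1 to compound 2 and a 2.3-fold lower number (0.36 log units; beyond the scatter) from compound 3 to compound 4, 2.5-fold (0.41 log units) apart, within the scatter of two such steps. For the compounds shown here, this rests on only two pairs in a single assay, so it does not show that the step would hold on any other core, and it says nothing about why the change lowers the number.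

The compounds shown leave open whether an ethyl group or a longer chain on this same ring nitrogen would take the number lower still, or would lose what methyl gained. They also leave open whether the step would survive if the carboxymethyl group were replaced by another group, such as a chain ending in an amine.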